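This account rests on a few compounds, and the source may have more. Where it says the series, first, only, none or still open, it means among the compounds named here.

Of the compounds shown here, three share one core and have been measured in a functional assay on CHO cells for antagonist activity at prostaglandin E2 receptor EP3 subtype (Homo sapiens), read by cAMP accumulation, with a stated time of 30 min; on this read-out higher numbers stand for weaker inhibition and lower numbers for stronger inhibition. Compound 1 `C/C(=C1/OC(=O)NC1=O)C(c1ccc(-c2ccc3cccc(F)c3c2)[nH]c1=O)C(C)C` gives 39 nM, the highest of the three numbers; compound 2 `CCC(CC)C(/C=C1\OC(=O)NC1=O)c1ccc(-c2ccc3cccc(F)c3c2)[nH]c1=O` gives 23 nM, within the scatter of compound 1, while compound 3 `O=C1NC(=O)/C(=C/C(c2ccc(-c3ccc4cccc(F)c4c3)[nH]c2=O)C2CCCCC2)O1` gives 8 nM, beyond it. Going by the values given here, the one step among them, a 2.9-fold lower number from compound 2 to compound 3 (0.46 log units; beyond the scatter), concerns the saturated chain carbon and not the ring. Compound 4 `CC(C)C(/C=C1\NC(=O)NC1=O)c1ccc(-c2ccc3cccc(F)c3c2)[nH]c1=O` differs from compound 1 by a group of 8 heavy atoms (4 carbon, 2 nitrogen, 2 oxygen; one five-membered non-aromatic ring with 2 hetero atoms) in place of a group of 9 heavy atoms (5 carbon, 1 nitrogen, 3 oxygen; one five-membered non-aromatic ring with 2 hetero atoms), on a saturated chain carbon bound to an aromatic carbon and a saturated chain carbon. Among the compounds with values here, no measured pair touches this ring, so nothing in the data points in either direction, and a step within the scatter is expected, a 1.0-fold higher number from compound 1 to compound 4 (0.01 log units; within the scatter), with wide uncertainty. For compound 4 the estimate in this assay is 40 nM, between 12 nM and 130 nM.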

Compound 4, half-maximal inhibitory concentration: 87 nM
Beside the measured number, compound 4's estimate is 2.2-fold (0.34 log units) below it; low and high end bracket the measured number.
By their numbers in this assay, from the lowest: compound 3; then compounds 2 and 1 (each within the scatter of the next); then compound 4.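

In this assay, replacing the group on the saturated chain carbon bound to an aromatic carbon and a saturated chain carbon changes the read-out beyond the scatter: a 2.2-fold higher number from compound 1 to compound 4 (0.35 log units; beyond the scatter). Going by these compounds alone, the one earlier step concerned only the substituent on the chain carbon, so this is the first sign that the five-membered non-aromatic ring group itself matters, though the step is modest. No measurement shown here offers an explanation for this step.

From the compounds shown here alone, whether the same ring exchange would give a similar step with cyclohexyl on the chain carbon remains open. Going by these compounds, it is also open how a carboxylic acid in place of the five-membered ring would compare.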